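Swapping a Cyclohexylmethyl for Methylsulfonyl on the Ring

A few compounds are considered here, and "the series" means these few. Any claim that something is new, unique, unknown or untested is made for them only; others in the source may bear on it.

Of the compounds shown here, two have so far been tested in a functional assay on the whole organism for inhibition, with Rattus norvegicus as the target, read by paw edema, with stated times of 1 h and 3 h, at a dose of 50 mg/kg by the oral route; a higher number here means more inhibition at the dose given (going by the name of the read-out), a lower number less inhibition. Compound 1, `C/C(=N\OCC(=O)O)c1ccccc1O`, gives only a limit in this assay, namely < 20%. Compound 2, `C/C(=N\OCC(=O)O)c1ccc(CC2CCCCC2)cc1`, likewise gives only a limit in this assay, namely < 20%. For the measured compounds named here, compound 2 thus stands at the limit itself, as the limit of < 20% in this assay, at which 2 of the 2 values shown sit, makes plain, and no measured step between compounds is available to show how a change of substituent moves the read-out. Compound 3, `C/C(=N\OCC(=O)O)c1ccc(S(C)(=O)=O)cc1`, differs from compound 2 in one place: methylsulfonyl in place of cyclohexylmethyl on an aromatic carbon. With nothing measured to lean on, only a small change is expected, none beyond the scatter, which a step that the limit leaves unreadable from compound 2 to compound 3 expresses. Compound 3 is therefore expected to give about 18% in this assay, within a range from 5% to 40%, and may well again be reported only as a limit.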

Compound 3, a percentage reported as inhibition, in the whole organism at one dose (the size of the read-out at that dose, not a potency): 20%
Estimate against measurement, compound 3: 2 percentage points below, and the stated range covers the measured number.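

Methylsulfonyl in place of cyclohexylmethyl on this aromatic carbon gives, in this assay, a number no lower from compound 2 to compound 3 (the limit leaves the size open). For the compounds shown here, compound 3 is the first compound here to carry a plain number rather than a limit, so this position accepts a group with no ring and with hydrogen-bond acceptors without any loss of inhibition. How much was gained cannot be read, and the gain may be very small, since the comparison rests on a limit: the limit of < 20% in this assay, at which 2 of the 3 values shown sit.

On these data alone, it remains open whether any group at this position can raise inhibition clearly, and whether the hydrogen-bond acceptors or the loss of the ring matter more. An amine or a carboxylic acid on the same carbon, or a longer carbon chain, would help separate these two possibilities.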